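The source may report more compounds than this note shows. Statements on the series, on what has been measured and on what is new or still open speak of the compounds shown alone.

Among the compounds with values here, in a functional assay on cells (Endothelial cell, Bos taurus) for antiproliferative activity (on this read-out lower numbers stand for stronger inhibition and higher numbers for weaker inhibition), compound 1 `COc1ccc(/C=C(\F)c2cc(OC)c(OC)c(OC)c2)cc1O` gives 13000 nM, the lower of the two numbers measured so far, while compound 2 `COc1ccc(/C(F)=C/c2cc(OC)c(OC)c(OC)c2)cc1O` gives 26600 nM. Compound 3 `COc1ccc(/C=C(\F)c2cc(OC)c(OC)c(OC)c2)cc1[N+](=O)[O-]` keeps the core of compound 1 and changes one group: nitro in place of hydroxy on an aromatic carbon. This puts nitro in place of hydroxy on an aromatic carbon, ortho to a methoxy group. Within the data shown here, no measured pair shows this swap, so the expectation is uncertain. The expected change in this assay, a 2.3-fold higher number from compound 1 to compound 3 (0.36 log units; beyond the scatter), is a small step toward weaker inhibition, slightly beyond the scatter. For compound 3 the estimated value is 30000 nM, with an expected range of 7000 nM to 100000 nM.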

Compound 3, half-maximal inhibitory concentration: 2800000 nM
Compound 3: the middle estimate sits 93-fold (1.97 log units) below what was measured; measured number outside the range, above it.
By their numbers in this assay, from the lowest: compound 1; then compound 2; then compound 3.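

In this assay, the position ortho to a methoxy group proves highly sensitive to its substituent: nitro in place of hydroxy gives a 220-fold higher number from compound 1 to compound 3 (2.33 log units; beyond the scatter) as a large move toward weaker inhibition. The swap replaces a hydrogen-bond donor with a larger group that has none, but this single pair cannot separate those differences. Nothing measured here gives a reason for the loss. Still open, from the compounds shown here alone, is whether an amine or a carboxylic acid at this position would hold the activity of compound 1 or lose it as well.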